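This account rests on a few compounds, and the source may have more. Where it says the series, first, only, none or still open, it means among the compounds named here.

Four compounds share one core. Compound 1 `COc1ccc(-c2c(C#N)[n+]([O-])c3ccccc3[n+]2[O-])cc1` was tested in an ADME assay on Vero cells (Chlorocebus sabaeus) for cytotoxicity, read by MTT assay, with a stated time of 72 h (a lower number here means a stronger inhibitor, a higher number a weaker inhibitor), and the entry for compound 1 reads "not determined" (no result reported). Compound 2 `COc1ccc(-c2c(C#N)[n+]([O-])c3cc(OC)ccc3[n+]2[O-])cc1` was likewise tested in this assay, and the entry for compound 2 reads "not determined" (no result reported). Compound 3 `COC(=O)c1ccc(-c2c(C#N)[n+]([O-])c3ccccc3[n+]2[O-])cc1` is the only one of the set with a number: in this assay compound 3 gives 4.8 ug/mL, which is therefore the sole reference point.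

Compound 4 `COC(=O)c1ccc(-c2c(C#N)[n+]([O-])c3cc(OC)ccc3[n+]2[O-])cc1` differs from compound 3 in a single place: methoxy in place of hydrogen on an aromatic carbon. No comparison among the measured compounds shows what this change does, so the direction of the step cannot be read from the data. The expectation is therefore a step of about a 1.1-fold higher number from compound 3 to compound 4 (0.06 log units; within the scatter), not clearly beyond the scatter, in either direction. For compound 4 in this assay the estimate is 5.5 ug/mL, within a range from 2 ug/mL to 14 ug/mL.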

Compound 4, half-maximal inhibitory concentration: 3.9 ug/mL
Beside the measured number, compound 4's estimate is 1.4-fold (0.15 log units) above it; measured number inside the range.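

In this assay, methoxy in place of hydrogen on this aromatic carbon gives a 1.2-fold lower number from compound 3 to compound 4 (0.09 log units; within the scatter). Going by these compounds alone, this is the first measured comparison for this change, and it shows that, with the methyl ester compounds, this position can carry methoxy with no clear difference in the read-out. Nothing measured here offers an explanation for this result.

The same change from compound 1 to compound 2 cannot be read, as neither compound has a number. Also open, going by these compounds, is how an amine, a carboxylic acid or a longer chain at this position would read.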